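A few compounds are considered here, and "the series" means these few. Any claim that something is new, unique, unknown or untested is made for them only; others in the source may bear on it.

Measured compounds:
compound 1 `O=c1[nH]c(=O)n([C@H]2C[C@H](O)[C@@H](CO)O2)cc1[N+](=O)[O-]` — 130 nM
compound 2 `Nc1nc(N)c2ncn([C@H]3CCCC[C@H]3CO)c2n1` — > 200000 nM

For the measured compounds named here, in an ADME assay on L1210/0 cells (Mus musculus) for cytotoxicity, with a stated time of 48 h (on this read-out lower numbers stand for stronger inhibition and higher numbers for weaker inhibition), compound 1 gives 130 nM, the only number in the set. Compound 2 reaches only a limit, > 200000 nM, not a number; this is the limit of > 200000 nM in this assay, at which 1 of the 2 values shown sits. Going by the values given here, no two measured compounds differ in just one place, so no step size between measured compounds is known.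

Compound 3 `O=c1[nH]c(=O)n([C@H]2C[C@H](O)[C@@H](CO)O2)cc1C1SCCS1` is still to be measured. It differs from compound 1 in one place: a group of 5 heavy atoms (3 carbon, 2 sulfur; one five-membered non-aromatic ring with 2 hetero atoms) in place of a group of 3 heavy atoms (1 nitrogen, 2 oxygen; no ring), on an aromatic carbon

With compound 1 as the only anchor in this assay, the expectation for the change from compound 1 to compound 3 is a loss of potency well beyond the usual scatter, as a step of a 150-fold higher number from compound 1 to compound 3 (2.19 log units; beyond the scatter). Compound 3 is therefore expected near 20000 nM, with a range from 2000 nM to 200000 nM, and a real chance that this assay returns only a limit for compound 3.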

Compound 3, half-maximal inhibitory concentration: > 200000 nM
Compound 3: no number, only a limit; the forecaster's own chance of this, stated with the estimate: 30%; middle value at least 10-fold (1.00 log units) away from the limit.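

For the compounds shown here, this aromatic carbon, on a six-membered aromatic ring, is the first place where a single change can be sized: in this assay, the five-membered non-aromatic ring with 2 hetero atoms in place of nitro gives an at least 1500-fold higher number from compound 1 to compound 3 (3.18 log units; beyond the scatter). Both groups count the same hydrogen-bond donors and acceptors and carry no net charge, so these counts do not separate them. Compound 3 gives a limit and not a number, so the step has only a lower bound: the limit of > 200000 nM in this assay, at which 2 of the 3 values shown sit.

Going by these compounds alone, with only two groups seen on this carbon, it remains open whether the activity of compound 1 is specific to nitro or would survive other replacements. A nitrile, an amine or a carboxylic acid here would help to separate these readings, and any measured number would give this position its first full step.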